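The compounds below may be only part of what the source reports. "The series", "measured", "known", "first", "only" and "open" are said of these compounds alone.

In a functional assay on CLL cells (Homo sapiens) for cytotoxicity, read by MTT assay, with a stated time of 48 h (on this read-out lower numbers stand for an effect already at smaller amounts and higher numbers for an effect only at larger amounts of compound), three compounds built on a shared core have been measured. Compound 1 (`C=C(CC)C(=O)c1ccc(OCC(=O)Nc2ccc(C(=O)O)c(O)c2)c(Cl)c1Cl`) gives > 25000 nM, which is a limit of the assay and not a number. Compound 2 (`C=C(CC)C(=O)c1ccc(OCC(=O)Nc2ccc(C(=O)O)cc2)c(Cl)c1Cl`) gives 5000 nM, and compound 3 (`C=C(CC)C(=O)c1ccc(OCC(=O)Nc2ccc(C(=O)OC)cc2)c(Cl)c1Cl`) gives 4100 nM. The step of a 1.2-fold lower number from compound 2 to compound 3 (0.09 log units; within the scatter) lies within the scatter, so compound 2 and compound 3 stand level, while compound 1 has only a limit.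

Compound 4 (`C=C(CC)C(=O)c1ccc(OCC(=O)NO)c(Cl)c1Cl`) has not yet been measured in this assay. It differs from compound 2 in one place: hydroxy in place of 4-carboxyphenyl on an amide-type nitrogen. The whole 4-carboxyphenyl group leaves, and hydroxy enters on an amide-type nitrogen.

Going by the values given here, two measured steps bear on this change, though only indirectly, since both alter the 4-carboxyphenyl group and neither removes it. The step of an at least 5.0-fold lower number from compound 1 to compound 2 (0.69 log units; beyond the scatter) lies beyond the scatter, so a change in that group can matter, whereas the step of a 1.2-fold lower number from compound 2 to compound 3 (0.09 log units; within the scatter) does not. Among the compounds with values here, no measured compound lacks the group, so the expectation starts from compound 2 at 5000 nM and must stay broad in both directions. The step expected is a 1.3-fold lower number from compound 2 to compound 4 (0.10 log units; within the scatter), which would not lie beyond the scatter. For compound 4 the estimated value is 4000 nM, with an expected range from 1200 nM to 15000 nM.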

Compound 4, half-maximal effective concentration: 4500 nM
Estimate against measurement, compound 4: 1.1-fold (0.05 log units) below; measured number inside the range.
By their numbers in this assay, from the lowest: compounds 3, 4 and 2 (each within the scatter of the next). At a limit, above all of these: compound 1.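

In this assay, the step of a 1.1-fold lower number from compound 2 to compound 4 (0.05 log units; within the scatter) shows that the whole 4-carboxyphenyl group on the amide-type nitrogen, with its 9 heavy atoms, can give way to a single hydroxy and leave the two compounds level. The earlier compounds shown here all kept this aromatic ring and changed only what it carries, and one such change gave the step of an at least 5.0-fold lower number from compound 1 to compound 2 (0.69 log units; beyond the scatter), so this part of the molecule looked as if it mattered in its own right. Compound 4 shows that the ring is not required for a number at the level of compound 2, and the one clear separation among these compounds remains the one that comes with the extra hydroxy on the ring of compound 1.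

What the compounds shown leave open is whether other groups on that nitrogen, such as a methyl, a longer chain such as an n-butyl, or a chain ending in an amine, would stand level with compound 2 or part from it. Compound 1 remains a limit and not a number, so the full size of its step stays unknown: the limit of > 25000 nM in this assay, at which 1 of the 4 values shown sits.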